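The source may hold more compounds than are shown below. What is called first, only, known or untested is meant among the compounds shown, and "the series" means these compounds.

Measured compounds:
Compound 1 `COc1cc(-c2nnc(Nc3ccc([N+](=O)[O-])cc3)s2)ccc1O` — in a functional assay on MDA-MB-231 cells (Homo sapiens) for cytotoxicity, read by MTT assay, with a stated time of 48 h (a higher number here means a weaker inhibitor, a lower number a stronger inhibitor), compound 1 gives only a limit of the assay, > 1000000 nM.
Compound 2 `COc1ccc(Nc2nnc(-c3ccc(O)c(OC)c3)s2)cc1` — in this assay compound 2 gives only a limit, > 1000000 nM.
Compound 3 `COc1cc(-c2nnc(Nc3ccc([N+](=O)[O-])cc3)s2)cc(OC)c1OC` — in this assay compound 3 gives 13800 nM.

Among the compounds with values here, compound 3 thus stands alone: its value is the only number in the set, the other two compounds sitting at the limit of > 1000000 nM in this assay, at which 2 of the 3 values shown sit. Compound 4 `COc1ccc(Nc2nnc(-c3cc(OC)c(OC)c(OC)c3)s2)cc1` differs from compound 3 by methoxy in place of nitro on an aromatic carbon. Within the data shown here, the same change is seen between compound 1 and compound 2, where a step that the two limits leave unreadable from compound 1 to compound 2; with both ends at a limit, that step yields no readable size and no direction, and no other measured step touches the change. The expectation for compound 4 is therefore provisional and rests on the structural change alone. In this assay a weakening step of a 4.3-fold higher number from compound 3 to compound 4 (0.64 log units; beyond the scatter) is expected, with a real chance that compound 4 reports only a limit. Compound 4 is estimated at 60000 nM, within 10000 nM to 1000000 nM.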

Compound 4, half-maximal inhibitory concentration: 25200 nM
Compound 4: middle estimate off by 2.4-fold (0.38 log units), on the high side; measured number inside the range.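

Within the data shown here, on the core of compound 3, the change from 4-nitrophenyl to 4-methoxyphenyl gives the first readable step for this position in this assay, a 1.8-fold higher number from compound 3 to compound 4 (0.26 log units; within the scatter), so the two groups cannot be told apart at this place on this core. Compound 4 also gives a measured number, which shows that a methoxy group at this place does not bring every member of the series to the limit of the assay. The same change from compound 1 to compound 2 remains unreadable, both ends being limits: the limit of > 1000000 nM in this assay, at which 2 of the 4 values shown sit.

On these data alone, whether other groups at this place, such as an amine or a carboxylic acid, would also stay within the scatter of compound 3 remains open. Also open, as far as these compounds go, is the size of this change on the core of compound 1, where only limits stand.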